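Swapping chloro for fluoro on the shared core

The source may report more compounds than this note shows. Statements on the series, on what has been measured and on what is new or still open speak of the compounds shown alone.

Measured so far:
- compound 1, `CCC(C)n1ccnc1-c1cccc(Cl)c1CCc1cc(Br)ccc1OC`: 2500 nM
- compound 2, `COc1ccc(Br)cc1CCc1c(Cl)cccc1-c1ncc2n1CCC2`: 180 nM

For the measured compounds named here, in an assay on isolated protein for binding affinity to Melanocortin receptor 4 (Homo sapiens) (a lower number here means a stronger inhibitor, a higher number a weaker inhibitor), compound 2 gives the lowest of the two numbers measured so far; its only neighbour is compound 1, and the change a 14-fold lower number from compound 1 to compound 2 (1.14 log units; beyond the scatter) sets the two apart by more than the usual scatter. Compound 3, `COc1ccc(Br)cc1CCc1c(F)cccc1-c1ncc2n1CCC2`, has not yet been measured. It keeps the core of compound 2 and changes one atom: fluoro in place of chloro on an aromatic carbon, with the place being an aromatic carbon of a six-membered aromatic ring of carbon only, ortho to a large group and meta to a group of 8 heavy atoms.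

Going by the values given here, no measured step bears directly on this change. Among the compounds with values here, the one known step, from compound 1 to compound 2, concerns the group of eight or nine heavy atoms at a different place on the core, so it says nothing about a halogen swap. With no guide, the expectation for compound 3 in this assay is a small step, a 1.7-fold higher number from compound 2 to compound 3 (0.22 log units; within the scatter), that may well lie within the scatter. Compound 3 is therefore estimated at 300 nM, with a range from 100 nM to 900 nM.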

Compound 3, inhibition constant: 320 nM
For compound 3 the middle estimate is 1.1-fold (0.03 log units) below the measured one; the range from low to high includes it.
By their numbers in this assay, from the lowest: compounds 2 and 3 (each within the scatter of the next); then compound 1.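

In this assay, exchanging chloro for fluoro on this aromatic carbon, ortho to a large group, gives a 1.8-fold higher number from compound 2 to compound 3 (0.25 log units; within the scatter), so the two halogens cannot be told apart at this place. For the compounds shown here, the earlier comparison concerned another place on the shared core, where a 14-fold lower number from compound 1 to compound 2 (1.14 log units; beyond the scatter) was large; this pair gives the first reading at the halogen position and shows that, for these two halogens, the choice leaves the number within the usual scatter of the measurement. No independent measurement is available to explain this result or to show what either halogen contributes at this place.

Chloro and fluoro are only two possible groups here, so a single pair cannot show how much this position would respond to a wider change, such as hydrogen, a nitrile, an amine or a carboxylic acid in place of the halogen. Going by these compounds, it also remains open whether fluoro and chloro would stay this close on the core of compound 1, which carries a different group at the other place.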